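Swapping the Chain-End Nitrile for an Oxime-Type Group

The source may hold more compounds than are shown below. What is called first, only, known or untested is meant among the compounds shown, and "the series" means these compounds.

Measured so far:
- Compound 1, `CCc1onc(NS(=O)(=O)c2ccc(C(C)(C)C)cc2)c1Sc1cccc(OC)c1`: in an assay on COS-7 cells for displacement of a labelled ligand from Endothelin receptor type B (Sus scrofa) (a lower number here means a stronger inhibitor, a higher number a weaker inhibitor), compound 1 gives 2800 nM.
- Compound 2, `COc1cccc(Sc2c(NS(=O)(=O)c3ccc(C(C)(C)C)cc3)noc2CCCC#N)c1`: in this assay compound 2 gives 520 nM.

Compound 2 holds the lower of the two numbers shown, and its only neighbour is compound 1. Going by the values given here, the single measured step, a 5.4-fold lower number from compound 1 to compound 2 (0.73 log units; beyond the scatter), was modest yet beyond the scatter, and it came from attaching cyanomethyl to the saturated chain.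

Compound 3, `COc1cccc(Sc2c(NS(=O)(=O)c3ccc(C(C)(C)C)cc3)noc2CCC/C=N/O)c1`, differs from compound 2 by a group of 3 heavy atoms (1 carbon, 1 nitrogen, 1 oxygen; no ring) in place of a group of 2 heavy atoms (1 carbon, 1 nitrogen; no ring), on a saturated chain carbon, three bonds along the chain from an aromatic carbon. Among the compounds with values here, no measured step mirrors this exchange. Within the data shown here, the one step on record touches the same chain end and shows that changes there can shift the number, but it gives no direction for replacing the cyano group. The expectation is therefore a step of about a 1.0-fold lower number from compound 2 to compound 3 (0.02 log units; within the scatter), that is, none beyond the scatter. Compound 3 is estimated at 500 nM, in the range 150 nM to 1700 nM.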

Compound 3, half-maximal inhibitory concentration: 85 nM
Estimate against measurement, compound 3: 5.9-fold (0.77 log units) above, and the stated range ends above it.
By their numbers in this assay, from the lowest: compound 3; then compound 2; then compound 1.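

In this assay, replacing the cyano group with the oxime-type group gives a 6.1-fold lower number from compound 2 to compound 3 (0.79 log units; beyond the scatter) and shows that the chain end is sensitive to which group sits there, not only to whether the chain carries a group at all. Taken as one change on the saturated chain carbon, the group that compound 3 carries there in place of a hydrogen atom gives a 33-fold lower number from compound 1 to compound 3 (1.52 log units; beyond the scatter) and is the largest step among these compounds. The entering group has 1 hydrogen-bond donor where cyano has 0, but no measurement here links that difference to the lower number.

On these data alone, whether another end group would do as well stays open, and an amine, a carboxylic acid or a primary amide at the same place would help to answer that. A longer chain or a shorter chain bearing the same oxime-type group would show how much the chain length matters.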